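The source may report more compounds than this note shows. Statements on the series, on what has been measured and on what is new or still open speak of the compounds shown alone.

Measured in an ADME assay on a cell-free system (plasma, Homo sapiens) for metabolic stability, read by HPLC; a lower number here means that the compound disappears faster, a higher number that the compound lasts longer:

Compound 1 `COC(=O)c1ccc(/N=N/N(C)C(=O)CCc2cccc(O)c2)cc1`: 7.8 h
Compound 2 `CN(/N=N/c1ccc(C(N)=O)cc1)C(=O)CCc1ccc(O)cc1`: 48.5 h
Compound 3 `Cc1ccc(/N=N/N(C)C(=O)CCCCc2ccc(O)cc2)cc1`: 79.7 h

Compound 2, at 48.5 h, lies within the scatter of compound 3 and well beyond the scatter above compound 1. Compound 4 `COC(=O)c1ccc(/N=N/N(C)C(=O)CCc2ccc(O)cc2)cc1` is compound 2 with methoxy in place of amino on a carbonyl carbon, carbamoyl to methoxycarbonyl (methoxy in place of amino on a carbonyl carbon). Going by the values given here, no measured pair isolates this change. Among the compounds with values here, the only guide is compound 1, the one measured compound that also carries methoxycarbonyl, at 7.8 h, although it differs elsewhere too. A shorter half-life is therefore expected, with an estimated 5.4-fold lower number from compound 2 to compound 4 (0.73 log units; beyond the scatter) beyond the scatter. For compound 4 the expected value is 9 h, with an estimated range of 3 h to 25 h.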

Compound 4, half-life: 7.3 h
Compound 4: the middle estimate sits 1.2-fold (0.09 log units) above what was measured, and the stated range covers the measured number.
By their numbers in this assay, from the lowest: compounds 4 and 1 (each within the scatter of the next); then compounds 2 and 3 (each within the scatter of the next).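

In this assay the change on this carbonyl carbon can now be read on its own: methoxy in place of amino gives a 6.6-fold lower number from compound 2 to compound 4 (0.82 log units; beyond the scatter) and lies beyond the scatter. The other new step, 4-hydroxyphenyl in place of 3-hydroxyphenyl, gives a 1.1-fold lower number from compound 1 to compound 4 (0.03 log units; within the scatter) and lies within the scatter. No measurement shown here accounts for the drop with methoxy. On these data alone, it remains open how a carboxylic acid or a methylamino group on this carbonyl carbon would compare, and whether the amino-to-methoxy step would hold on a longer chain.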